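Replacing Nitro with Trifluoromethyl on the Aromatic Ring

The source may hold more compounds than are shown below. What is called first, only, known or untested is meant among the compounds shown, and "the series" means these compounds.

Of the compounds shown here, three that share one core have been tested so far, and they differ only in the aromatic group on a carbonyl carbon. In a functional assay on MCF7 cells (Homo sapiens) for antiproliferative activity, read by MTT assay, with a stated time of 72 h (a lower number here means a stronger inhibitor, a higher number a weaker inhibitor), compound 1 `CC1=CC[C@H]2[C@H](CC[C@]2(C)O)C(C)(C)[C@@H]1CC[C@H]1[C@]2(C)CC[C@H](OC(=O)c3ccc([N+](=O)[O-])cc3)C(C)(C)O[C@H]2CC[C@@]1(C)O` gives 21600 nM as its value. In this assay compound 2 `CC1=CC[C@H]2[C@H](CC[C@]2(C)O)C(C)(C)[C@@H]1CC[C@H]1[C@]2(C)CC[C@H](OC(=O)c3ccccc3Cl)C(C)(C)O[C@H]2CC[C@@]1(C)O` gives 12100 nM as its value. Compound 3 `CC1=CC[C@H]2[C@H](CC[C@]2(C)O)C(C)(C)[C@@H]1CC[C@H]1[C@]2(C)CC[C@H](OC(=O)c3ccccc3[N+](=O)[O-])C(C)(C)O[C@H]2CC[C@@]1(C)O` gives 5200 nM, the lowest of the three numbers.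

The next compound is compound 4 `CC1=CC[C@H]2[C@H](CC[C@]2(C)O)C(C)(C)[C@@H]1CC[C@H]1[C@]2(C)CC[C@H](OC(=O)c3ccccc3C(F)(F)F)C(C)(C)O[C@H]2CC[C@@]1(C)O`. It differs from compound 3 in a single group: trifluoromethyl in place of nitro on an aromatic carbon. In words, trifluoromethyl stands in place of nitro on an aromatic carbon, ortho to a large group.

The closest evidence is a swap on that same carbon, where nitro replacing chloro gave a 2.3-fold lower number from compound 2 to compound 3 (0.37 log units; beyond the scatter) in this assay. Shifting the nitro group on the ring gave a 4.2-fold lower number from compound 1 to compound 3 (0.62 log units; beyond the scatter), so the ring pattern can matter here. The remaining comparison, a 1.8-fold lower number from compound 1 to compound 2 (0.25 log units; within the scatter), adds little. Among the compounds with values here, no trifluoromethyl compound has been measured yet, so the forecast rests on one observation: the only other group tested on that carbon, in compound 2, sits higher at 12100 nM.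

A modest rise is therefore expected, an estimated 1.8-fold higher number from compound 3 to compound 4 (0.26 log units; within the scatter) in this assay. For compound 4 the expected value is 9500 nM, with an estimated range from 4000 nM to 20000 nM.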

Compound 4, half-maximal inhibitory concentration: 19200 nM
Compound 4: middle estimate off by 2.0-fold (0.31 log units), on the low side; low and high end bracket the measured number.
By their numbers in this assay, from the lowest: compound 3; then compounds 2, 4 and 1 (each within the scatter of the next).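

In this assay the nitro group of compound 3 proves hard to replace on this aromatic carbon: trifluoromethyl gives a 3.7-fold higher number from compound 3 to compound 4 (0.57 log units; beyond the scatter) and this step lies beyond the scatter, so among the three groups placed here, nitro alone stands apart. The other two steps lie within the scatter: trifluoromethyl and chloro on this carbon cannot be told apart, with a 1.6-fold higher number from compound 2 to compound 4 (0.20 log units; within the scatter) in this comparison, and the 2-(trifluoromethyl)phenyl ester cannot be told apart from the 4-nitrophenyl ester, with a 1.1-fold lower number from compound 1 to compound 4 (0.05 log units; within the scatter) in that one, so the better number of compound 3 does not extend to every group at this place on the ring. Nothing available here explains why nitro behaves differently from the other two groups.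

Going by these compounds, whether a nitrile, an amine or a carboxylic acid on this same carbon would fall with nitro, or with chloro and trifluoromethyl, remains open. On these data alone, it is also open whether this order of compounds would hold in cell types other than the one tested here.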